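The compounds below may be only part of what the source reports. "The series", "measured", "known", "first", "only" and "open" are said of these compounds alone.

Measured so far:
- compound 1 `O=C(O)CCn1c(=O)oc2cc(Cl)c(Cl)cc21`: in a physicochemical assay for permeability, using PAMPA (on this read-out higher numbers stand for higher permeability and lower numbers for lower permeability), compound 1 gives 24 nm/s
- compound 2 `O=C(O)CCn1c(=O)oc2cc(OCc3ccccc3)c(Cl)cc21`: in this assay compound 2 gives "not determined" (no result reported)
- compound 3 `O=C(O)CCn1c(=O)oc2cc(OCc3ccccn3)c(Cl)cc21`: in this assay compound 3 gives 11 nm/s

Compound 1 stands highest of the two numbers available; the nearest is compound 3, with a 2.2-fold lower number from compound 1 to compound 3 (0.34 log units; beyond the scatter). Compound 2 has no number and gives no bearing.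

Compound 4 `CCOc1cc2oc(=O)n(CCC(=O)O)c2cc1Cl` is not yet measured. Its change from compound 1 is ethoxy in place of chloro on an aromatic carbon. Within the data shown here, the only measured step that bears on it is a 2.2-fold lower number from compound 1 to compound 3 (0.34 log units; beyond the scatter), also an exchange of chloro for an oxygen-linked group at the same place, though the entering group there carried a ring. A smaller entering group here gives no further measured guide, so a step of similar direction but lesser size is expected in this assay: the expected step is a 1.6-fold lower number from compound 1 to compound 4 (0.20 log units; within the scatter). Compound 4 is estimated at 15 nm/s, between 7 nm/s and 32 nm/s.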

Compound 4, apparent permeability: < 10 nm/s
Compound 4: a limit, no number; the forecaster's own chance of this, stated with the estimate: 5%; middle value at least 1.5-fold (0.17 log units) from the limit.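

In this assay compound 4 stands at a limit and not a number: the limit of < 10 nm/s in this assay, at which 1 of the 4 values shown sits. Even ethoxy, which has no ring, gives an at least 2.4-fold lower number from compound 1 to compound 4 (0.38 log units; beyond the scatter), so at this position the lower read-out does not depend on a ring in the group entering for chloro. With an at least 1.1-fold lower number from compound 3 to compound 4 (0.04 log units; that floor lies within the scatter), no order can be read between ethoxy and (pyridin-2-yl)methoxy.

As far as these compounds go, whether a fluoro group, a nitrile or an amine at this position would keep the read-out of compound 1 stays open. From the compounds shown here alone, the full size of the step to compound 4 also stays open.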